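Hexylsulfanyl for 4-methylpiperidinyl: expected potency of compound 4

The source may report more compounds than this note shows. Statements on the series, on what has been measured and on what is new or still open speak of the compounds shown alone.

Compound 1 `CC1CCN(c2cc(C(F)(F)F)ccc2CNC(=O)C(C)c2ccc(NS(C)(=O)=O)c(F)c2)CC1` gives 0.9 nM in an assay on CHO cells for antagonist activity at transient receptor potential cation channel subfamily V member 1 (Homo sapiens), read by FLIPR (on this read-out lower numbers stand for stronger inhibition and higher numbers for weaker inhibition), the highest of the three numbers, though its neighbours sit within the scatter: compound 2 `CCCCCCOc1cc(C(C)(F)F)ccc1CNC(=O)C(C)c1ccc(NS(C)(=O)=O)c(F)c1` gives 0.8 nM and compound 3 `CC(C(=O)NCc1ccc(C(F)(F)F)cc1OC1CCCCC1)c1ccc(NS(C)(=O)=O)c(F)c1` gives 0.7 nM in this assay. Compound 4 `CCCCCCSc1cc(C(F)(F)F)ccc1CNC(=O)C(C)c1ccc(NS(C)(=O)=O)c(F)c1` carries hexylsulfanyl in place of 4-methylpiperidin-1-yl on an aromatic carbon. Among the measured compounds shown here, the one measured step touching the same position, a 1.3-fold lower number from compound 1 to compound 3 (0.11 log units; within the scatter), shows that exchanging the 4-methylpiperidin-1-yl group for another seven-heavy-atom substituent left this assay essentially unchanged; compound 2, which bears a hexyloxy chain there, likewise sits within the scatter of compound 1. No step beyond the scatter is therefore expected for compound 4, and the estimated step is a 1.1-fold lower number from compound 1 to compound 4 (0.05 log units; within the scatter). Compound 4 is expected to give about 0.8 nM, within a range from 0.3 nM to 2.5 nM.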

Compound 4, inhibition constant: 1.8 nM
Compound 4: the middle estimate sits 2.3-fold (0.35 log units) below what was measured, and the stated range covers the measured number.
By their numbers in this assay, from the lowest: compounds 3, 2, 1 and 4 (each within the scatter of the next, the first and the last beyond it).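

Hexylsulfanyl gives the first step at this position that lies beyond the scatter in this assay, though a modest one (a 2.6-fold higher number from compound 3 to compound 4 (0.41 log units; beyond the scatter)), whereas the step from the piperidine stays within it (a 2.0-fold higher number from compound 1 to compound 4 (0.30 log units; within the scatter)). The position therefore tells these substituents apart only slightly, and the open chain with sulfur remains well tolerated. Nothing available here accounts for the step.

As far as these compounds go, compound 3 and compound 4 differ in both the linking atom and the ring, so which of the two matters stays open. A cyclohexylsulfanyl group would separate them.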